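A few compounds are considered here, and "the series" means these few. Any claim that something is new, unique, unknown or untested is made for them only; others in the source may bear on it.

In a functional assay on HepG2 cells (Homo sapiens) for cytotoxicity, read by MTT assay, with a stated time of 48 h (a lower number here means a stronger inhibitor, a higher number a weaker inhibitor), compound 1 `Cc1ncc([N+](=O)[O-])n1CCSc1nnc(-c2ccc(N)cc2)o1` gives 6700 nM and compound 2 `CCOc1ccccc1-c1nnc(SCCn2c([N+](=O)[O-])cnc2C)o1` gives 9800 nM, two values within the scatter of each other. Compound 3 `Cc1ncc([N+](=O)[O-])n1CCSc1nnc(-c2ccccc2[N+](=O)[O-])o1` gives 700 nM, clearly lower than both. Compound 4 `Cc1ncc([N+](=O)[O-])n1CCSc1nnc(-c2ccc(Cl)cc2)o1` keeps the core of compound 1 and carries chloro in place of amino on an aromatic carbon. Among the measured compounds shown here, the only measured step, a 14-fold lower number from compound 2 to compound 3 (1.15 log units; beyond the scatter), is large but involves other groups, so it bears only loosely on this change. A moderate move to a lower number is expected, and the estimated step is a 2.2-fold lower number from compound 1 to compound 4 (0.35 log units; beyond the scatter). For compound 4, the expected value is 3000 nM, with an estimated range of 900 nM to 9000 nM.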

Compound 4, half-maximal inhibitory concentration: 7800 nM
Compound 4: the middle estimate sits 2.6-fold (0.41 log units) below what was measured; the range from low to high includes it.
By their numbers in this assay, from the lowest: compound 3; then compounds 1, 4 and 2 (each within the scatter of the next).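

In this assay, chloro in place of amino on the aromatic carbon para to a large group gives a 1.2-fold higher number from compound 1 to compound 4 (0.07 log units; within the scatter). In this one pair, the hydrogen-bond donor and acceptor counted for amino can therefore go without a step beyond the scatter. Nothing measured here accounts for this result.

As far as these compounds go, whether a carboxylic acid or a longer chain at this same place would also stay within the scatter remains open. So does what nitro, the group carried by compound 3 on its aromatic ring, would give here.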